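The compounds below may be only part of what the source reports. "The series", "measured", "known", "first", "only" and "open" are said of these compounds alone.

In a functional assay on MDA-MB-231 cells (Homo sapiens) for inhibition, read by resazurin assay, with a stated time of 72 h (on this read-out lower numbers stand for stronger inhibition and higher numbers for weaker inhibition), compound 1 `Clc1ccccc1-c1ccc(-n2cc(-c3ccccc3)nn2)cc1` stands at "not determined" (no result reported). Compound 2 `Clc1ccccc1-c1ccn2ncnc2n1` reaches only a limit of this assay at > 100000 nM, a boundary rather than a measured number, the same boundary described by the limit of > 100000 nM in this assay, at which 1 of the 2 values shown sits. Compound 3 `c1ccc(-c2ccn3ncnc3n2)cc1` differs from compound 2 by hydrogen in place of chloro on an aromatic carbon. Within the data shown here, no measured step exists between these compounds, so the loss of a single chlorine is expected to leave the result roughly where compound 2 left it, an expected step that the limit leaves unreadable from compound 2 to compound 3. Compound 3 is therefore estimated at 150000 nM, most likely between 50000 nM and 500000 nM, and quite possibly again reported only as a limit.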

Compound 3, half-maximal inhibitory concentration: > 100000 nM
Compound 3: no number, only a limit; the forecaster's own chance of this, stated with the estimate: 85%; the middle value does not contradict the limit.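

Compound 2 and compound 3 both stop at a limit rather than a number, so no step between them can be read: the limit of > 100000 nM in this assay, at which 2 of the 3 values shown sit.

What the compounds shown leave open is whether hydrogen in place of chloro changes the inhibition at all.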